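Chain extension on the acyl tail of the sulfonamide series

The source may hold more compounds than are shown below. What is called first, only, known or untested is meant among the compounds shown, and "the series" means these compounds.

Among the compounds with values here, compound 1 `CCC(=O)N1CCC(NS(=O)(=O)c2ccc(NC(=O)c3ccccc3C)c3ccccc23)CC1` gives 2.5 nM in an assay on L1.2 cells for binding affinity to C-C chemokine receptor type 8 (Homo sapiens) (on this read-out lower numbers stand for stronger inhibition and higher numbers for weaker inhibition), the lowest of the three numbers measured so far. Compound 2 `Cc1ccccc1C(=O)Nc1ccc(S(=O)(=O)NC2CCN(C(=O)CN)CC2)c2ccccc12` gives 4.1 nM and compound 3 `Cc1ccccc1C(=O)Nc1ccc(S(=O)(=O)NC2CCN(C(=O)CCCCN)CC2)c2ccccc12` gives 199 nM. The step of a 1.6-fold higher number from compound 1 to compound 2 (0.21 log units; within the scatter) stays within the scatter, whereas an 80-fold higher number from compound 1 to compound 3 (1.90 log units; beyond the scatter) and a 49-fold higher number from compound 2 to compound 3 (1.69 log units; beyond the scatter) are both large. Compound 4 `CCN(CC)CCCC(=O)N1CCC(NS(=O)(=O)c2ccc(NC(=O)c3ccccc3C)c3ccccc23)CC1` differs from compound 1 by (diethylamino)methyl in place of hydrogen on a saturated chain carbon, two bonds along the chain from a carbonyl carbon. The step from compound 1 to compound 3 bears most directly on this change, since it likewise places an amine-bearing chain on a saturated chain carbon two bonds along the chain from a carbonyl carbon and gave an 80-fold higher number from compound 1 to compound 3 (1.90 log units; beyond the scatter). A weaker number is therefore expected for compound 4, perhaps not quite as far out, estimated at 40 nM with a range of 8 nM to 200 nM, which means an expected step of a 16-fold higher number from compound 1 to compound 4 (1.20 log units; beyond the scatter).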

Compound 4, inhibition constant: 567 nM
For compound 4 the middle estimate is 14-fold (1.15 log units) below the measured one; the measured number lies above the stated range.
By their numbers in this assay, from the lowest: compounds 1 and 2 (each within the scatter of the next); then compound 3; then compound 4.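

In this assay, a long amine-bearing tail stays far from the short acyl groups even when its end is diethylamino rather than amino: a 230-fold higher number from compound 1 to compound 4 (2.36 log units; beyond the scatter) and a 140-fold higher number from compound 2 to compound 4 (2.14 log units; beyond the scatter). Diethylamino in place of aminomethyl adds only a modest further loss, a 2.8-fold higher number from compound 3 to compound 4 (0.45 log units; beyond the scatter), so alkyl groups on the end nitrogen recover nothing here. The large losses therefore extend to both amine-ended long chains shown.

Nothing at hand bears on the origin of these losses. On these data alone, whether a hydroxyl or carboxylic acid ending the same chain would behave like these amines stays open.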